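Thiophene sulfonyl replaces cyclopropylcarbonyl in a weak series

The source may hold more compounds than are shown below. What is called first, only, known or untested is meant among the compounds shown, and "the series" means these compounds.

Measured in a functional assay on HeLa cells (Homo sapiens) for antiproliferative activity, read by MTT assay, with a stated time of 48 h; a lower number here means a stronger inhibitor, a higher number a weaker inhibitor:
Compound 1 `COc1ccc(C(=O)Nc2ccc3ncc(-c4cnn(C)c4)cc3n2)cc1`: 4900 nM
Compound 2 `COc1ccc(CNc2ccc3ncc(-c4cnn(C)c4)cc3n2)cc1`: > 50000 nM (a limit)
Compound 3 `Cn1cc(-c2cnc3ccnc(NC(=O)C4CC4)c3c2)cn1`: > 50000 nM (a limit)

Compound 3 has no exact number. Its > 50000 nM is a limit of this assay. The same limit recurs across this small set: the limit of > 50000 nM in this assay, at which 2 of the 3 values shown sit.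

Compound 4 `Cn1cc(-c2cnc3ccnc(NS(=O)(=O)c4cccs4)c3c2)cn1` carries (thiophen-2-yl)sulfonyl in place of cyclopropylcarbonyl on a nitrogen on an aromatic ring.

Going by the values given here, no measured pair shows this change, so the size of the step is uncertain. Only compound 1, at 4900 nM, gives an exact number. The expected step of an at least 1.6-fold lower number from compound 3 to compound 4 (0.22 log units; that floor lies within the scatter) is small, towards a stronger inhibitor, and may not show at all. The estimate for compound 4 is 30000 nM, with an expected range from 6000 nM to 100000 nM.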

Compound 4, half-maximal inhibitory concentration: 17400 nM
Beside the measured number, compound 4's estimate is 1.7-fold (0.24 log units) above it, within the range that was stated.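

In this assay, placing (thiophen-2-yl)sulfonyl instead of cyclopropylcarbonyl on the nitrogen on an aromatic ring gives an at least 2.8-fold lower number from compound 3 to compound 4 (0.45 log units; beyond the scatter), so activity at this position responds to the group it carries. Compound 4 gives this group an exact number, whereas compound 3 has only a limit, so the true size of the step remains unknown: the limit of > 50000 nM in this assay, at which 2 of the 4 values shown sit.

The compounds shown do not separate the part played by the sulfonyl link from that of the thiophene ring. A methanesulfonyl group or a thiophene-2-carbonyl group on this nitrogen would pull those two apart.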